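The source may report more compounds than this note shows. Statements on the series, on what has been measured and on what is new or still open speak of the compounds shown alone.

Measured compounds in an assay on HEK293 cells for displacement of a labelled ligand from Melanocortin receptor 4 (Homo sapiens); on this read-out lower numbers stand for stronger inhibition and higher numbers for weaker inhibition:
compound 1 `COc1ccc(OCC(=O)N2CCN(c3ccc(C(F)(F)F)cc3[C@@H](N)CC(C)C)CC2)cc1` gives 3800 nM
compound 2 `COc1cc(Cl)ccc1C[C@@H](C)C(=O)N1CCN(c2ccc(C)cc2[C@@H](N)CC(C)C)CC1` gives 8.1 nM

Of the two numbers in this assay, compound 1 carries the highest; compound 2 sits far beneath it, and the two structures differ in several places at once, so the gap between them is noted without being tied to any single change.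

Compound 3 `CC(C)C[C@H](N)c1cc(C(F)(F)F)ccc1N1CCN(C(=O)COc2cccc(Cl)c2Cl)CC1` is not yet measured in this assay. It differs from compound 1 in one place: 2,3-dichlorophenyl in place of 4-methoxyphenyl on an oxygen on a saturated carbon. Among the compounds with values here, no measured pair carries this change, so nothing in the data says how large the step should be or in which direction. Resting only on compound 1 and its 3800 nM, a step from compound 1 to compound 3 of a 1.9-fold lower number from compound 1 to compound 3 (0.28 log units; within the scatter) is expected, small and not clearly beyond the scatter. Compound 3 is therefore estimated at 2000 nM in this assay, with a range from 400 nM to 9000 nM.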

Compound 3, inhibition constant: 2500 nM
Beside the measured number, compound 3's estimate is 1.3-fold (0.10 log units) below it; measured number inside the range.
By their numbers in this assay, from the lowest: compound 2; then compounds 3 and 1 (each within the scatter of the next).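

In this assay, 2,3-dichlorophenyl in place of 4-methoxyphenyl on an oxygen on a saturated carbon gives a 1.5-fold lower number from compound 1 to compound 3 (0.18 log units; within the scatter) and so does not separate the two compounds. Within the data shown here, this is the first reading at this position: two differently substituted phenyl groups, one with a hydrogen-bond acceptor and one with none, are not told apart on the core of compound 1, and both numbers remain in the same high range. Nothing measured bears on why the exchange leaves the two compounds within the scatter.

On these data alone, only these two phenyl groups have been seen at this position, so it remains open whether a ring bearing an amine or a carboxylic acid would move the number beyond the scatter from compound 1. As far as these compounds go, a longer chain in place of the (4-methoxyphenoxy)methyl group is equally open.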